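Compound 3: a ring-free group replaces that of compound 2

The compounds below may be only part of what the source reports. "The series", "measured", "known", "first", "only" and "open" are said of these compounds alone.

Compound 1 `CCCCNC(=S)NC1=C(C#N)C(c2ccc(Cl)cc2Cl)C2=C(CCCC2=O)N1c1ccc(S(N)(=O)=O)cc1`: > 100 ug/mL (a limit)
Compound 2 `N#CC1=C(NC(=S)Nc2ccc(Br)cc2)N(c2ccc(S(N)(=O)=O)cc2)C2=C(C(=O)CCC2)C1c1ccc(Cl)cc1Cl`: 25 ug/mL

Within the data shown here, in a functional assay on Ehrlich cells (Mus musculus) for cytotoxicity, read by trypan blue exclusion, with a stated time of 2 h (a higher number here means a weaker inhibitor, a lower number a stronger inhibitor), compound 2 gives 25 ug/mL, the only actual number so far. For compound 1 the assay returned only a limit, > 100 ug/mL. The other result shown is thus (the limit of > 100 ug/mL in this assay, at which 1 of the 2 values shown sits).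

Compound 3 `N#CC1=C(NC(=O)CCC(=O)O)N(c2ccc(S(N)(=O)=O)cc2)C2=C(C(=O)CCC2)C1c1ccc(Cl)cc1Cl` is still unmeasured and differs from compound 2 in one place: a group of 7 heavy atoms (4 carbon, 3 oxygen; no ring) in place of a group of 10 heavy atoms (7 carbon, 1 nitrogen, 1 sulfur, 1 bromine; one six-membered aromatic ring of carbon only), on an amine nitrogen. Among the measured compounds shown here, the aromatic ring that leaves carries the 4-bromophenyl group, and that group figures in the single measured step that bears on this change. That step is an at least 4.0-fold lower number from compound 1 to compound 2 (0.60 log units; beyond the scatter), with 4-bromophenyl in place of butyl on an amide-type nitrogen. Compound 3 also lacks this ring, so, given an at least 4.0-fold lower number from compound 1 to compound 2 (0.60 log units; beyond the scatter), a move towards a higher number in this assay is expected, and another limit would not be surprising. The expected step is a 2.8-fold higher number from compound 2 to compound 3 (0.45 log units; beyond the scatter). For compound 3 the estimate is 70 ug/mL, with an expected range of 25 ug/mL to 200 ug/mL.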

Compound 3, half-maximal inhibitory concentration: 50 ug/mL
Compound 3: the middle estimate sits 1.4-fold (0.15 log units) above what was measured; the measured number falls inside the stated range.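

In this assay, placing the ring-free (2-carboxyethyl)carbonyl group on this amine nitrogen gives a 2.0-fold higher number from compound 2 to compound 3 (0.30 log units; within the scatter), so an aromatic ring at this place is not required for a measured number to be reached. The earlier step from butyl to 4-bromophenyl, an at least 4.0-fold lower number from compound 1 to compound 2 (0.60 log units; beyond the scatter), could be read as a gain tied to the ring, but that reading no longer stands on its own now that a group with no ring also gives an actual number. Set against the butyl group, the (2-carboxyethyl)carbonyl group gives an at least 2.0-fold lower number from compound 1 to compound 3 (0.30 log units; that floor lies within the scatter), and only a floor can be stated for this step, whose true size stays unknown: the limit of > 100 ug/mL in this assay, at which 1 of the 3 values shown sits.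

On these data alone, it remains open whether a methyl ester in place of the carboxylic acid, or a longer chain ending in the acid, would give a number like that of compound 3. As far as these compounds go, it is equally open whether an unsubstituted phenyl or a 4-chlorophenyl group would match the number of compound 2 at this place.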